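The compounds below may be only part of what the source reports. "The series", "measured", "known", "first", "only" and "open" are said of these compounds alone.

Compound 1 `COc1ccc(-c2nc3ccccc3n2CCCN2CCC(c3cccc(NC(C)=O)c3)CC2)cc1` gives 9 nM in an assay for displacement of a labelled ligand from melanin-concentrating hormone receptor 1 (Homo sapiens), read by fluorescence; on this read-out lower numbers stand for stronger inhibition and higher numbers for weaker inhibition. Compound 2 `CCc1ccc(-c2nc3ccccc3n2CCCN2CCC(c3cccc(NC(C)=O)c3)CC2)cc1`, which carries an ethyl in place of the methoxy on an aromatic carbon, gives 32 nM in this assay; the step of a 3.6-fold higher number from compound 1 to compound 2 (0.55 log units; beyond the scatter) is modest but beyond the scatter. Compound 2 therefore stands with the highest of the two numbers recorded so far, its nearest neighbour being compound 1. Compound 3 `CC(=O)Nc1cccc(C2CCN(CCCn3c(-c4ccc(F)cc4Cl)nc4ccccc43)CC2)c1` differs from compound 2 in one place: 2-chloro-4-fluorophenyl in place of 4-ethylphenyl on an aromatic carbon. For the measured compounds named here, the only measured step that bears on this change is the one leading from compound 1 to compound 2, which shows that exchanging the substituent on this aromatic ring moved the number modestly. A change of similar size, in either direction, is expected for compound 3, meaning an estimated step of a 1.6-fold lower number from compound 2 to compound 3 (0.20 log units; within the scatter). Compound 3 is expected to give about 20 nM, with a range from 5 nM to 80 nM.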

Compound 3, half-maximal inhibitory concentration: 4 nM
Compound 3: the middle estimate sits 5.0-fold (0.70 log units) above what was measured; the whole stated range lies above it.
By their numbers in this assay, from the lowest: compound 3; then compound 1; then compound 2.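

In this assay, the aryl group on this aromatic carbon of the five-membered aromatic ring with 2 nitrogen can lower the number as well as raise it: 2-chloro-4-fluorophenyl gives an 8.0-fold lower number from compound 2 to compound 3 (0.90 log units; beyond the scatter) and also a 2.3-fold lower number from compound 1 to compound 3 (0.35 log units; beyond the scatter), leaving compound 3 with the lowest number of the three. The entering and leaving groups have the same count of heavy atoms and neither has a hydrogen-bond donor or acceptor, so these counts do not separate 2-chloro-4-fluorophenyl from 4-ethylphenyl. Nothing available accounts for the size or direction of these steps.

From the compounds shown here alone, what a 2-chlorophenyl or a 4-fluorophenyl group alone would give remains open, so the parts played by the chlorine and the fluorine cannot be told apart. Also open, going by these compounds, is how an amine or a carboxylic acid on this aromatic ring would read.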